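This account rests on a few compounds, and the source may have more. Where it says the series, first, only, none or still open, it means among the compounds named here.

Compound 2 `Cc1c(OC[C@@H](C)COc2ccc(C(=O)O)c(F)c2)ccc(C(=O)CC(C)(C)C)c1O` gives 1090 nM in an assay for positive allosteric modulation of metabotropic glutamate receptor 3 (Rattus norvegicus) (a lower number here means that less compound is needed, a higher number that more compound is needed for the effect), the lower of the two numbers shown, though within the scatter of compound 1 `Cc1c(OC[C@@H](C)COc2ccc(Cl)c(C(=O)O)c2)ccc(C(=O)CC(C)(C)C)c1O`, which gives 2200 nM; the step of a 2.0-fold lower number from compound 1 to compound 2 (0.30 log units; within the scatter) is within the scatter. Compound 3 `COc1ccccc1OC[C@H](C)COc1ccc(C(=O)CC(C)(C)C)c(O)c1C` is unmeasured. The change is 2-methoxyphenyl in place of 4-carboxy-3-fluorophenyl on an oxygen on a saturated carbon. Among the measured compounds shown here, no measured step removes a carboxylic acid; the one step available, a 2.0-fold lower number from compound 1 to compound 2 (0.30 log units; within the scatter), only rearranged substituents on that ring and gives little guidance. The expected step is a 3.7-fold higher number from compound 2 to compound 3 (0.56 log units; beyond the scatter), most likely toward a higher number with wide uncertainty. Compound 3 is estimated at 4000 nM, between 800 nM and 20000 nM.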

Compound 3, half-maximal effective concentration: "not active" (no number reported)
For compound 3 the study gives words and no number, and the estimate cannot be compared.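

No new step can be read: in this assay compound 3 is reported as "not active" without a number, so it cannot be set against compound 2. The compounds shown leave open whether any 2-methoxyphenyl compound gives a measurable number in this assay. No available evidence bears on this result.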